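The source may hold more compounds than are shown below. What is called first, only, known or untested is meant among the compounds shown, and "the series" means these compounds.

Compound 1 `Cc1nc2ncc(-c3cnn(C)c3)nc2n1Cc1ccc2ncccc2c1`: > 10000 nM
Compound 2 `Cn1cc(-c2cnc3nc(O)n(Cc4ccc5ncccc5c4)c3n2)cn1`: > 10000 nM
Compound 3 `Cc1c(C(C)n2cnc3ncc(-c4cn[nH]c4)nc32)ccc2ncccc12`: 599 nM

These compounds were tested in a functional assay on NCI-H1993 cells (Homo sapiens) for inhibition, read by CCK-8 assay, with a stated time of 72 h; on this read-out higher numbers stand for weaker inhibition and lower numbers for stronger inhibition. In this assay compound 2 gives > 10000 nM, which is a limit of the assay and not a number. Compound 1 gives > 10000 nM, which is also a limit. Among the measured compounds shown here, compound 3 gives 599 nM, the only true number among the three. Compound 2 therefore has no exact place on the scale, and the background to its result is the limit of > 10000 nM in this assay, at which 2 of the 3 values shown sit.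

The next compound, compound 4 `Oc1nc2ncc(-c3ccccc3)nc2n1Cc1ccc2ncccc2c1`, carries phenyl in place of 1-methyl-1H-pyrazol-4-yl on an aromatic carbon. For the measured compounds named here, the one measured step between compounds differing in one place is a step that the two limits leave unreadable from compound 1 to compound 2. That step involves hydroxy in place of methyl, a different exchange, so it supplies no size to carry over. Going by the values given here, no measured step exchanges 1-methyl-1H-pyrazol-4-yl for phenyl.

With no evidence for a gain, the expectation is that the result stays close to the limit of compound 2, with no clear direction of change. The expected size of the change is a step that the limit leaves unreadable from compound 2 to compound 4. For compound 4 the estimate is 12000 nM, with an expected range from 3000 nM to 40000 nM.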

Compound 4, half-maximal inhibitory concentration: > 10000 nM
Compound 4 ended at the assay's limit; the forecaster's own chance of this, stated with the estimate: 75%; the middle value lies beyond the limit too.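

Compound 2 and compound 4 both give limits of the assay and not numbers, so the exchange of 1-methyl-1H-pyrazol-4-yl for phenyl yields no step of readable size, and the same ceiling recurs: the limit of > 10000 nM in this assay, at which 3 of the 4 values shown sit.

The compounds shown leave open how far past that limit compound 2 and compound 4 lie, and whether this exchange changes inhibition at all.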